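A few compounds are considered here, and "the series" means these few. Any claim that something is new, unique, unknown or untested is made for them only; others in the source may bear on it.

- Compound 1 `COc1ccc(CN(C(=O)Cn2cc(CSc3nncs3)nn2)c2cc(OC)c(OC)c(OC)c2)cc1`: 16500 nM
- Compound 2 `COc1ccc(CN(C(=O)Cn2cc(CSc3nnnn3C)nn2)c2cc(OC)c(OC)c(OC)c2)cc1`: 10900 nM

Both values come from a functional assay on PC-3 cells (Homo sapiens) for antiproliferative activity, read by MTT assay, with a stated time of 48 h; a higher number here means a weaker inhibitor, a lower number a stronger inhibitor. The two compounds share a core and differ only in the ring carried on a sulfur. Compound 2, at 10900 nM, has only compound 1 to be compared with. The gap between the two is within the scatter of repeated measurements. They cannot be ranked.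

The next compound, compound 3 `COc1ccc(CN(C(=O)Cn2cc(Cn3ccc4ccccc43)nn2)c2cc(OC)c(OC)c(OC)c2)cc1`, carries 1H-indol-1-yl in place of (1-methyl-1H-tetrazol-5-yl)sulfanyl on a saturated chain carbon bound to an aromatic carbon. Among the compounds with values here, only one measured step offers any guide, a 1.5-fold lower number from compound 1 to compound 2 (0.18 log units; within the scatter). That step swapped one ring on a sulfur for another, whereas this change also removes the sulfur, so it is only a loose guide. Within the data shown here, no measured compound here carries 1H-indol-1-yl, so the direction is open and no step beyond the scatter is expected in this assay. The expected change is a 1.4-fold lower number from compound 2 to compound 3 (0.13 log units; within the scatter), an estimate with wide uncertainty. For compound 3 the estimated value is 8000 nM, with an expected range of 2500 nM to 25000 nM.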

Compound 3, half-maximal inhibitory concentration: 2390 nM
Beside the measured number, compound 3's estimate is 3.3-fold (0.52 log units) above it, and the stated range ends above it.
By their numbers in this assay, from the lowest: compound 3; then compounds 2 and 1 (each within the scatter of the next).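

In this assay, within the data shown here, this position proves able to move the read-out: putting 1H-indol-1-yl on the saturated chain carbon bound to an aromatic carbon gives the first changes beyond the scatter, both modest in size (a 4.6-fold lower number from compound 2 to compound 3 (0.66 log units; beyond the scatter) and a 6.9-fold lower number from compound 1 to compound 3 (0.84 log units; beyond the scatter)). The two sulfur-linked rings could not be ranked against each other, so exchanging one such ring for another showed nothing at this position, whereas the larger exchange does: the sulfur leaves, and a single five-membered aromatic ring with 4 hetero atoms gives way to a five-membered aromatic ring with 1 hetero atom plus a six-membered aromatic ring of carbon only. Several features therefore change in one step, and no measurement here accounts for the stronger inhibition.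

The compounds shown leave open whether the loss of the sulfur or the 1H-indol-1-yl group itself carries the change; a 1H-indol-1-yl group reached through a sulfur, or a phenyl ring or an amine such as piperidin-1-yl on the same carbon, would help separate the two. Also open, as far as these compounds go, is whether a second fused benzene ring or a substituent on the 1H-indol-1-yl group would extend the step further.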